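The source may hold more compounds than are shown below. What is called first, only, known or untested is meant among the compounds shown, and "the series" means these compounds.

Measured compounds:
- compound 1, `CCOc1cc(NC(=O)C2(NC(=O)c3ccc4c(C5CCCC5)c(-c5ncc(Cl)cn5)n(C)c4c3)CCC2)ccc1/C=C/C(=O)OCOP(=O)(O)OC(C)(C)C`, giving 1.48 h in an ADME assay (liver) for pharmacokinetics, with Liver microsome (Homo sapiens) as the target, using microsomes; a lower number here means that the compound disappears faster, a higher number that the compound lasts longer
- compound 2, `CCOC(=O)/C=C/c1ccc(NC(=O)C2(NC(=O)c3ccc4c(C5CCCC5)c(-c5ncc(Cl)cn5)n(C)c4c3)CCC2)cc1OCC`, for which this assay reports only a limit, > 5 h
- compound 3, `CCCCCCOC(=O)/C=C/c1ccc(NC(=O)C2(NC(=O)c3ccc4c(C5CCCC5)c(-c5ncc(Cl)cn5)n(C)c4c3)CCC2)cc1OCC`, giving 17.9 h in this assay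

Compound 3 holds the highest of the two readable numbers; its nearest neighbour is compound 1, and the gap is a 12-fold higher number from compound 1 to compound 3 (1.08 log units; beyond the scatter). The value of compound 2 is a limit of this assay, not a number (the limit of > 5 h in this assay, at which 1 of the 3 values shown sits).

Compound 4, `CCOc1cc(NC(=O)C2(NC(=O)c3ccc4c(C5CCCC5)c(-c5ncc(Cl)cn5)n(C)c4c3)CCC2)ccc1/C=C/C(=O)OCc1ccccc1`, differs from compound 3 in one place: phenyl in place of pentyl on a saturated chain carbon bound to an oxygen next to a carbonyl group. Going by the values given here, two measured steps touch the same position. The exchange in compound 1 gave a 12-fold higher number from compound 1 to compound 3 (1.08 log units; beyond the scatter) and an at least 3.3-fold higher number from compound 1 to compound 2 (0.52 log units; beyond the scatter), each a shift upward when the phosphorus-bearing group was replaced by a small carbon group. The remaining step, a step that the limit leaves unreadable from compound 2 to compound 3, cannot be read because of the limit. Compound 4 swaps one carbon-only group for another of nearly the same size, a change smaller in kind than either readable step. Compound 4 is therefore expected to stay close to compound 3, with a step of a 1.5-fold lower number from compound 3 to compound 4 (0.17 log units; within the scatter) that may not exceed the scatter. The estimate for compound 4 is 12 h, with a range from 5 h to 30 h.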

Compound 4, half-life: > 5 h
Compound 4 gave a limit, no number (the forecaster's own chance of this, stated with the estimate: 25%); the middle value does not contradict the limit.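

Compound 3 carries hexyloxycarbonyl where compound 4 carries benzyloxycarbonyl, and in this assay compound 4 gives > 5 h, and this is a limit of the assay, not a number. Replacing the phosphorus-bearing group with the phenyl-bearing group still gives an at least 3.3-fold higher number from compound 1 to compound 4 (0.52 log units; beyond the scatter), so among the compounds shown, the rise seen with the carbon-only groups of compound 2 and compound 3 is not confined to open chains and also appears with a six-membered aromatic ring of carbon only. The steps from compound 2 and from compound 3 to compound 4 cannot be read, so the carbon-only groups at this place cannot be put in order, and a second compound now sits at the same limit: the limit of > 5 h in this assay, at which 2 of the 4 values shown sit.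

The compounds shown leave open whether phenyl at this place lasts as long as pentyl does in compound 3, which gives 17.9 h. They also leave open how a phenyl ring carrying an amine or a carboxylic acid, or a chain longer than hexyl, would read in this assay.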